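The compounds below may be only part of what the source reports. "The series", "measured", "known", "first", "only" and "open" are said of these compounds alone.

Of the compounds shown here, three built on one shared core have been tested in a functional assay on MCF7 cells (Homo sapiens) for inhibition, read by sulforhodamine B assay, with a stated time of 72 h; on this read-out higher numbers stand for weaker inhibition and lower numbers for stronger inhibition. Compound 1 `COc1ccc2cc(C(C)c3nnc4n3N=C(c3ccc([N+](=O)[O-])cc3)CS4)ccc2c1` gives 18800 nM. Compound 2 `COc1ccc2cc(C(C)c3nnc4n3N=C(c3ccc(Br)cc3)CS4)ccc2c1`, with bromo in place of nitro on an aromatic carbon, gives 11500 nM. That change is a 1.6-fold lower number from compound 1 to compound 2 (0.21 log units; within the scatter). Compound 3 `CC(c1ccc(-c2ccccc2)c(F)c1)c1nnc2n1N=C(c1ccccc1)CS2`, which carries a different arm on the core and a plain phenyl, gives 7400 nM, the lowest of the three numbers: its gap to compound 2 is within the scatter, while its gap to compound 1 lies beyond it.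

Compound 4 `CC(c1ccc(-c2ccccc2)c(F)c1)c1nnc2n1N=C(c1ccc(Cl)cc1)CS2` is compound 3 with chloro in place of hydrogen on an aromatic carbon, the whole change reading phenyl to 4-chlorophenyl. Among the measured compounds shown here, the only measured change on that ring, a 1.6-fold lower number from compound 1 to compound 2 (0.21 log units; within the scatter), exchanged one group for another at the same place and stayed within the scatter. For the measured compounds named here, no measured pair exchanges hydrogen for a halogen on that ring. The expected step of a 1.2-fold lower number from compound 3 to compound 4 (0.09 log units; within the scatter) is therefore none beyond the scatter. Compound 4 is expected to give about 6000 nM, within a range from 2500 nM to 18000 nM.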

Compound 4, half-maximal inhibitory concentration: 8700 nM
Beside the measured number, compound 4's estimate is 1.5-fold (0.16 log units) below it; measured number inside the range.
By their numbers in this assay, from the lowest: compounds 3, 4, 2 and 1 (each within the scatter of the next, the first and the last beyond it).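

In this assay, chloro in place of hydrogen on this aromatic carbon, para to a large group, gives a 1.2-fold higher number from compound 3 to compound 4 (0.07 log units; within the scatter), so the two compounds cannot be told apart. The earlier pair only exchanged one group for another at this place, with a 1.6-fold lower number from compound 1 to compound 2 (0.21 log units; within the scatter); this new pair shows that putting a chlorine on the plain phenyl also leaves the number within the scatter, so neither of the two changes measured on this ring gives a step beyond it. Nothing measured here goes further than these numbers to explain that result.

Going by these compounds, whether a different kind of group at this place, such as an amine or a carboxylic acid, would give a step beyond the scatter remains open. Among the compounds shown here, also open is whether chloro in place of hydrogen gives an equally small step on the other arm, the one carried by compound 1 and compound 2.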